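The source may report more compounds than this note shows. Statements on the series, on what has been measured and on what is new or still open speak of the compounds shown alone.

Measured so far:

- Compound 1 `COc1ccc(C(=O)Nc2cc3nc(C4CCCCC4)[nH]c3cc2N(C)C)cc1`: in an ADME assay on Vero cells (Chlorocebus sabaeus) for cytotoxicity, read by resazurin assay, with a stated time of 3 days (a lower number here means a stronger inhibitor, a higher number a weaker inhibitor), compound 1 gives > 100 ug/mL, which is a limit of the assay rather than a number.
- Compound 2 `COc1ccc(C(=O)Nc2cc3nc(C4CCCCC4)[nH]c3cc2N2CCCC2)cc1`: in this assay compound 2 gives > 100 ug/mL, again a limit.
- Compound 3 `CCCC(C)OC(=O)Nc1cc2nc(C3CCCCC3)[nH]c2cc1N(CC)CC`: in this assay compound 3 gives > 100 ug/mL, also a limit.

Where compound 2 stands is therefore known only as a limit: none of the three compounds produced a readable number, as the limit of > 100 ug/mL in this assay, at which 3 of the 3 values shown sit, states. Among the measured compounds shown here, the one measured step, a step that the two limits leave unreadable from compound 1 to compound 2, cannot be read for size or direction, since both of its ends are limits.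

Compound 4 `O=C(NCc1ccccc1)Nc1cc2nc(C3CCCCC3)[nH]c2cc1N1CCCC1` is reached from compound 2 by a change on the carbonyl carbon that carries the amide-type nitrogen: benzylamino in place of 4-methoxyphenyl on a carbonyl carbon. For the measured compounds named here, no measured step touches this part of the molecule, so nothing here shows whether such a change moves the read-out at all. Going by the values given here, the only guide is that every compound made so far sits at the limit.

On that basis the expectation for compound 4 is that it also stays at the limit, so the step of a number no higher from compound 2 to compound 4 (the limit leaves the size open) is expected to be none beyond the scatter. The estimate for compound 4 is 100 ug/mL, within the range 40 ug/mL to 250 ug/mL.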

Compound 4, half-maximal inhibitory concentration: > 100 ug/mL
Compound 4 ended at the assay's limit; the forecaster's own chance of this, stated with the estimate: 75%; the middle value lies on the limit itself.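

No new step can be read: compound 2 and compound 4 both give only a limit rather than a number in this assay, so the change between them has no readable size or direction: the limit of > 100 ug/mL in this assay, at which 4 of the 4 values shown sit.

The compounds shown leave open whether any change to these structures would give a readable number in this assay.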